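Phenyl to Pyridin-4-yl Swap Carried Over to a Second Core

The compounds below may be only part of what the source reports. "The series", "measured", "known", "first", "only" and "open" are said of these compounds alone.

Three compounds were tested in an assay on isolated protein for inhibition of Gonadotropin-releasing hormone receptor (Homo sapiens); on this read-out lower numbers stand for stronger inhibition and higher numbers for weaker inhibition. Compound 1 `COc1ccc([N+](=O)[O-])cc1CSc1nc2cc(NC(=O)NC(C)(C)C)ccc2n1Cc1ccccc1` gives 28 nM in this assay. Compound 2 `COc1ccc([N+](=O)[O-])cc1CSc1nc2cc(NC(=O)NC(C)(C)C)ccc2n1Cc1ccncc1` differs from compound 1 by pyridin-4-yl in place of phenyl on a saturated chain carbon bound to an aromatic nitrogen; in this assay compound 2 gives 47 nM. The step of a 1.7-fold higher number from compound 1 to compound 2 (0.22 log units; within the scatter) shows that this change cost little. Compound 3 `CCCn1c(SCc2cc([N+](=O)[O-])ccc2OC)nc2cc(NC(=O)NC(C)(C)C)cc(C(=O)NCc3ccccc3)c21` is built on a different core, and the difference between the two cores is not broken down here; in this assay compound 3 gives 120 nM, the highest of the three numbers, beyond the scatter from both compound 1 and compound 2.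

Compound 4 `CCCn1c(SCc2cc([N+](=O)[O-])ccc2OC)nc2cc(NC(=O)NC(C)(C)C)cc(C(=O)NCc3ccncc3)c21` has not yet been measured. It differs from compound 3 by pyridin-4-yl in place of phenyl on a saturated chain carbon bound to an amide-type nitrogen. This is the same kind of change as that from compound 1 to compound 2, but the place is not the same: there the saturated chain carbon is bound to an aromatic nitrogen, here it is bound to an amide-type nitrogen. Among the measured compounds shown here, the step is expected to be a 1.5-fold higher number from compound 3 to compound 4 (0.18 log units; within the scatter) in this assay, beside the earlier 1.7-fold higher number from compound 1 to compound 2 (0.22 log units; within the scatter), resting on the one precedent within the scatter and on the value of compound 3 at 120 nM. Compound 4 is therefore expected to give about 180 nM in this assay, within a range from 80 nM to 400 nM.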

Compound 4, half-maximal inhibitory concentration: 61 nM
Compound 4: middle estimate off by 3.0-fold (0.47 log units), on the high side; measured number below the stated range.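

In this assay, putting pyridin-4-yl in place of phenyl on a saturated chain carbon bound to an amide-type nitrogen gives a 2.0-fold lower number from compound 3 to compound 4 (0.29 log units; within the scatter), so this step alone does not separate the two compounds. Its meaning lies in the comparison with the earlier step, and the two steps differ by more than their scatter: the same change on two cores in this assay, a 1.7-fold higher number (0.22 log units; within the scatter) from compound 1 to compound 2 and a 2.0-fold lower number (0.29 log units; within the scatter) from compound 3 to compound 4, 3.3-fold (0.52 log units) apart, beyond the scatter of two such steps. Among the compounds shown here, this shows that, in this series, the step measured on the core of compound 1 did not serve as a reliable guide to the step on the core of compound 3, but it does not show that pyridin-4-yl helps on one core and hurts on the other, since each step alone lies within the scatter, and with only two pairs, which also differ in the place of the change, the gap cannot be assigned to the core or to the place.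

The compounds shown leave open whether pyridin-3-yl or pyridin-2-yl in place of phenyl would give steps like those of pyridin-4-yl at either place. They also leave open how the change behaves when it is made at one and the same place on both cores.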